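From Nitro to Methoxycarbonyl on a Weak Compound

The source may hold more compounds than are shown below. What is called first, only, known or untested is meant among the compounds shown, and "the series" means these compounds.

Measured so far in a functional assay on KYSE-450 cells (Homo sapiens) for inhibition, read by MTT assay, with a stated time of 48 h; on this read-out lower numbers stand for stronger inhibition and higher numbers for weaker inhibition
Compound 1 `C/C=C/C(=O)N(Cc1ccc(OC)c([N+](=O)[O-])c1)c1cc(OC)c(OC)c(OC)c1` gives 510 nM
Compound 2 `COc1ccc(CNc2cc(OC)c(OC)c(OC)c2)cc1[N+](=O)[O-]` gives 16800 nM
Compound 3 `COc1ccc(CN(C(=O)C(C)Br)c2cc(OC)c(OC)c(OC)c2)cc1O` gives 160 nM

Compound 2 has the highest number of the three, so it is the weakest inhibitor of the set. Compound 4 `COC(=O)c1cc(CNc2cc(OC)c(OC)c(OC)c2)ccc1OC` differs from it in one place: methoxycarbonyl in place of nitro on an aromatic carbon. Methoxycarbonyl stands in place of nitro on an aromatic carbon, ortho to a methoxy group.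

Among the measured compounds shown here, only one measured step connects these compounds, and it concerns another part of the molecule. The large step of a 33-fold higher number from compound 1 to compound 2 (1.52 log units; beyond the scatter) comes with hydrogen in place of (prop-1-en-1-yl)carbonyl on a nitrogen. Compound 4 keeps that hydrogen, so compound 2 at 16800 nM is the natural starting point. For the measured compounds named here, no measured pair tests the replacement of nitro, so the size of this step is unknown, and the default expectation in this assay is no change beyond the scatter, in either direction. The expected step is small: a 1.2-fold lower number from compound 2 to compound 4 (0.08 log units; within the scatter). For compound 4 the estimate is 14000 nM, with an expected range from 4000 nM to 50000 nM.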

Compound 4, half-maximal inhibitory concentration: 41100 nM
Beside the measured number, compound 4's estimate is 2.9-fold (0.47 log units) below it; the measured number falls inside the stated range.
By their numbers in this assay, from the lowest: compound 3; then compound 1; then compound 2; then compound 4.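

Among the compounds shown here, the earlier step concerned only the nitrogen, so this is the first reading of this ring position, ortho to a methoxy group, in this assay: with methoxycarbonyl in place of nitro there is a 2.4-fold higher number from compound 2 to compound 4 (0.39 log units; beyond the scatter), a modest change, so the position is not indifferent to the swap. The two groups share the same counts of hydrogen-bond donors and acceptors, a double bond outside aromatic rings and no net charge, so none of these counts separates them. Nothing available here explains the rise in the number.

The compounds shown leave open how a carboxylic acid or an amine would read at this position. They also leave open whether this step would keep its size with the (prop-1-en-1-yl)carbonyl of compound 1 on the nitrogen.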